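Replacing a charged group with hydroxy on the aryl ring

A few compounds are considered here, and "the series" means these few. Any claim that something is new, unique, unknown or untested is made for them only; others in the source may bear on it.

Compound 1 `COC(=O)C1=C(C)N=C(C)/C(=C(\O)OC)C1c1cccc([N+](C)(C)C)c1` carries a group of 4 heavy atoms with a net charge on its aromatic ring. Within the data shown here, in a functional assay (muscle tissue) with Cavia porcellus as the target (on this read-out higher numbers stand for an effect only at larger amounts of compound and lower numbers for an effect already at smaller amounts), compound 1 gives 50100 nM, the highest of the three numbers measured so far. Compound 2 `COC(=O)C1=C(C)N=C(C)/C(=C(\O)OC)C1c1cccc(I)c1` gives 41.7 nM in this assay, and compound 3 `COC(=O)C1=C(C)N=C(C)/C(=C(\O)OC)C1c1ccc(Br)cc1` gives 540 nM. Compound 4 `COC(=O)C1=C(C)N=C(C)/C(=C(\O)OC)C1c1cccc(O)c1` has not yet been measured; it differs from compound 1 by one oxygen atom in place of a group of 4 heavy atoms (3 carbon, 1 nitrogen; no ring), on an aromatic carbon. The step that bears most directly on it is a 1200-fold lower number from compound 1 to compound 2 (3.08 log units; beyond the scatter), where the same group left the ring but an iodine atom entered instead of a hydroxy. The step of a 13-fold higher number from compound 2 to compound 3 (1.11 log units; beyond the scatter) shows that the choice and placement of the group on the ring can also shift the number considerably. Since a hydroxy is a different replacement from an iodine, a large drop in the number is expected for compound 4, though a smaller one than in the iodine case: the expected step is a 50-fold lower number from compound 1 to compound 4 (1.70 log units; beyond the scatter). Compound 4 is therefore estimated at 1000 nM, with a range from 150 nM to 7000 nM.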

Compound 4, half-maximal effective concentration: 1000 nM
For compound 4 middle estimate and measured number coincide at the digits printed, and the stated range covers the measured number.
By their numbers in this assay, from the lowest: compound 2; then compounds 3 and 4 (each within the scatter of the next); then compound 1.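

In this assay, losing the charged group lowers the number even when the group that enters is only a hydroxy, with no net charge: a 50-fold lower number from compound 1 to compound 4 (1.70 log units; beyond the scatter). The large drop is therefore not special to iodine, yet the two uncharged replacements are not equal on this aromatic carbon, as the hydroxy-for-iodo change gives a 24-fold higher number from compound 2 to compound 4 (1.38 log units; beyond the scatter). Compound 4 also cannot be told apart from the 4-bromophenyl compound, with a 1.9-fold higher number from compound 3 to compound 4 (0.27 log units; within the scatter), although that comparison changes both the group and its place on the ring, so it cannot be credited to either alone.

Nothing available here bears on what lies behind these steps. Going by these compounds, whether a methoxy or an amine on the same aromatic carbon would give a number nearer that of compound 2 or compound 4 remains open.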